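The source may report more compounds than this note shows. Statements on the series, on what has been measured and on what is new or still open speak of the compounds shown alone.

Measured so far:
- compound 1, `N#Cc1cnc(NCc2cnccc2C(F)(F)F)cc1NC[C@H]1C[C@H](O)C1`: > 10000 nM
- compound 2, `N#Cc1cnc(NCc2cncnc2-c2ccccc2)cc1N[C@H]1CC[C@@H](O)CC1`: 90 nM

Compound 1 was tested in an assay on isolated protein for inhibition of protein kinase C delta type (Homo sapiens), read by TR-FRET, with a stated time of 2 h; a lower number here means a stronger inhibitor, a higher number a weaker inhibitor. For compound 1 the result is a limit of the assay and not a number, > 10000 nM, so all that is known is that it sits at the limit of > 10000 nM in this assay, at which 1 of the 2 values shown sits. Compound 2 gives 90 nM in this assay, a clear number. Among the compounds with values here, compound 2 differs from compound 1 in more than one place, so no single step between them can be counted, and the two values are simply what they are.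

Compound 3, `CC1(C)C[C@@H](Nc2cc(NCc3cnccc3C(F)(F)F)ncc2C#N)CC[C@@H]1O`, has not yet been measured. It differs from compound 1 in one place, (4-hydroxy-3,3-dimethylcyclohexyl in place of (3-hydroxycyclobutyl)methyl on a nitrogen on an aromatic ring). Since compound 1 is known only as a limit, the size of this step cannot be drawn from a measured pair. The expectation is that the number moves downward, toward stronger inhibition, by a step of about an at least 5.0-fold lower number from compound 1 to compound 3 (0.69 log units; beyond the scatter). Compound 3 is estimated at 2000 nM, with a range from 300 nM to 10000 nM in this assay.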

Compound 3, half-maximal inhibitory concentration: 2400 nM
Compound 3: middle estimate off by 1.2-fold (0.08 log units), on the low side; the range from low to high includes it.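

The earlier compounds shown here gave only a limit for this series with the trifluoromethyl-bearing side of compound 1, so nothing yet showed that the group on this nitrogen could bring a readable value. In this assay, putting 4-hydroxy-3,3-dimethylcyclohexyl in place of (3-hydroxycyclobutyl)methyl on the nitrogen gives an at least 4.1-fold lower number from compound 1 to compound 3 (0.61 log units; beyond the scatter), so with the rest of the molecule held the same, this one place is enough to move the result from a limit to a measured number. The true size of the step remains unknown, because the result for compound 1 is a limit of the assay and not a number: the limit of > 10000 nM in this assay, at which 1 of the 3 values shown sits.

The compounds shown do not separate the parts of this change, so the six-membered ring, the two methyl groups and the loss of the methyl link between ring and nitrogen could each carry some or all of the step. They also leave open whether the hydroxy group on the ring matters at all, and whether an amine or a carboxylic acid in its place would keep, raise or lose this inhibition.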